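Adding a Second Methoxy to Compound 1

A few compounds are considered here, and "the series" means these few. Any claim that something is new, unique, unknown or untested is made for them only; others in the source may bear on it.

Compounds measured so far:
compound 1, `COc1ccc(-c2cc(/C=C/C(=O)c3ccc(N)cc3)[nH]n2)cc1`: 12%
compound 2, `COc1cc(-c2cc(/C=C/C(=O)c3ccc(Cl)c(Cl)c3)[nH]n2)cc(OC)c1OC`: 46%
compound 3, `COc1cc(-c2cc(/C=C/C(=O)c3ccc(F)c(F)c3)[nH]n2)cc(OC)c1OC`: -13%

In a functional assay on TK-10 cells (Homo sapiens) for cytotoxicity, read by sulforhodamine B assay, with a stated time of 48 h, tested at 10 uM (a higher number here means a weaker effect of the compound at the concentration tested, a lower number a stronger effect), compound 1 gives 12%, the second highest of the three numbers. Compound 3 lies nearest to it, with -13%, and compound 2 furthest, with 46%. For the measured compounds named here, the only step between two compounds that differ in one place is a number 59 percentage points lower from compound 2 to compound 3 (beyond the scatter); it concerns the ring on the carbonyl carbon, not the ring on the shared core, so it does not bear on the change studied here.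

Compound 4, `COc1ccc(-c2cc(/C=C/C(=O)c3ccc(N)cc3)[nH]n2)cc1OC`, is not yet measured. It differs from compound 1 by methoxy in place of hydrogen on an aromatic carbon. Going by the values given here, no measured pair shows what such a change does in this assay, and the one large step on record sits elsewhere in the molecule. Compound 4 is therefore expected to stay close to compound 1, with a step of a number 2 percentage points lower from compound 1 to compound 4 (within the scatter), not beyond the scatter. The estimate for compound 4 is 10%, ranging from -15% to 35%.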

Compound 4, a percentage reported as activity, at one concentration (the size of the read-out at that concentration, not a potency): 56%
Beside the measured number, compound 4's estimate is 46 percentage points below it; measured number outside the range, above it.
By their numbers in this assay, from the lowest: compound 3; then compound 1; then compounds 2 and 4 (each within the scatter of the next).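

In this assay the methoxy in place of hydrogen, ortho to a methoxy group and meta to a large group, gives a number 44 percentage points higher from compound 1 to compound 4 (beyond the scatter) and so weakens the effect of the compound at the concentration tested. For the compounds shown here, this is the first pair to show that a change on this aromatic ring can move the read-out by a large amount, since the only earlier step concerned the ring on the carbonyl carbon. Nothing available explains why this single added group has so large an effect.

From the compounds shown here alone, whether a hydroxyl group or an ethoxy chain on the same carbon would act as the methoxy does remains open. So does whether the step would hold with chlorine or fluorine in place of the amine on the ring on the carbonyl carbon.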